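This account rests on a few compounds, and the source may have more. Where it says the series, first, only, none or still open, it means among the compounds named here.

In a physicochemical assay for solubility, using the shake flask method, in simulated intestinal fluid, measured as kinetic solubility, with a stated time of 2 h, at 25 degrees C, at pH 6.5 (on this read-out higher numbers stand for higher solubility and lower numbers for lower solubility), compound 1 `Cc1noc(-c2nc(C)c3c(c2N)C(=O)N(CC2CCOCC2)C3=O)n1` gives 5700 nM. Compound 2 `Cc1noc(-c2nc(C)c3c(c2N)C(=O)N(Cc2ccc(Cl)cn2)C3=O)n1` gives < 5000 nM, which is a limit of the assay and not a number. Compound 3 `Cc1noc(-c2nc(C)c3c(c2N)C(=O)N(Cc2ccc(CO)cc2)C3=O)n1` differs from compound 2 by 4-(hydroxymethyl)phenyl in place of 5-chloropyridin-2-yl on a saturated chain carbon bound to an amide-type nitrogen in a ring, with 4-(hydroxymethyl)phenyl in place of 5-chloropyridin-2-yl. Going by the values given here, only one measured step changes the group at this place, an at least 1.1-fold lower number from compound 1 to compound 2 (0.05 log units; that floor lies within the scatter), and its floor lies within the scatter. That step gives no reason to expect a change beyond the scatter in this assay. The estimated step is an at least 1.1-fold higher number from compound 2 to compound 3 (0.04 log units; that floor lies within the scatter), with no clear direction expected. For compound 3 the expected value is 5500 nM, with an estimated range of 3000 nM to 12000 nM.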

Compound 3, solubility: < 5000 nM
Compound 3 ended at the assay's limit; the forecaster's own chance of this, stated with the estimate: 45%; middle value at least 1.1-fold (0.04 log units) away from the limit.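

In this assay compound 3 gives < 5000 nM, which is a limit of the assay and not a number. Going by these compounds alone, with 4-(hydroxymethyl)phenyl, as with 5-chloropyridin-2-yl, on a saturated chain carbon bound to an amide-type nitrogen in a ring, the read-out stays at a limit, so the step between these two groups cannot be read, and the one readable change is an at least 1.1-fold lower number from compound 1 to compound 3 (0.05 log units; that floor lies within the scatter). A second aromatic ring at this place thus ends at the same limit: the limit of < 5000 nM in this assay, at which 2 of the 3 values shown sit. Going by these compounds, how far the two limited compounds lie from that limit remains open. So does the outcome with an amine or a carboxylic acid at this place.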